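Methoxy for methyl on the second core

The source may hold more compounds than are shown below. What is called first, only, known or untested is meant among the compounds shown, and "the series" means these compounds.

Compound 1 `Cc1ccc2nc(NC(C)C)nc(NCc3ccco3)c2c1` and compound 2 `Cc1cccc2nc(NC(C)C)nc(NCc3ccco3)c12` are built from the same atoms joined differently; the difference between the two cores is not broken down here. In a physicochemical assay for permeability, using PAMPA, at pH 7.4 (on this read-out lower numbers stand for lower permeability and higher numbers for higher permeability), compound 1 gives 789 10^-6 cm/s and compound 2 gives 812 10^-6 cm/s, two numbers within the scatter of each other. Compound 3 `COc1ccc2nc(NC(C)C)nc(NCc3ccco3)c2c1` carries methoxy in place of methyl on an aromatic carbon and in this assay gives 1010 10^-6 cm/s, so that step is a 1.3-fold higher number from compound 1 to compound 3 (0.11 log units; within the scatter). Compound 4 `COc1cccc2nc(NC(C)C)nc(NCc3ccco3)c12` carries methoxy in place of methyl on an aromatic carbon, the same kind of change on the core of compound 2, the place differing in that it is ortho to a fused ring and meta to a fused ring rather than meta and para. For compound 4 the step is expected to be a 1.2-fold higher number from compound 2 to compound 4 (0.09 log units; within the scatter), beside the earlier one, because compound 3 gave 1010 10^-6 cm/s after the same kind of change. Compound 4 is therefore estimated at 1000 10^-6 cm/s, within 650 10^-6 cm/s to 1500 10^-6 cm/s.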

Compound 4, apparent permeability: 624 10^-6 cm/s
The estimate for compound 4 lay 1.6-fold (0.20 log units) above the measured number; measured number outside the range, below it.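

In this assay, methoxy in place of methyl gives a 1.3-fold higher number from compound 1 to compound 3 (0.11 log units; within the scatter) on one core and a 1.3-fold lower number from compound 2 to compound 4 (0.11 log units; within the scatter) on the other. Both steps lie within the scatter, so on these two cores the change leaves the read-out within repeat-measurement noise, and the pair does not establish that the two cores or the two places respond differently, nor that they respond alike. Nothing available bears on the reason for this result.

From the compounds shown here alone, whether a larger step would appear on either core with a carboxylic acid or an amine on this aromatic carbon remains open. So does whether a step seen with such a group would carry from one core to the other.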